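A few compounds are considered here, and "the series" means these few. Any claim that something is new, unique, unknown or untested is made for them only; others in the source may bear on it.

Measured compounds:
- compound 1 `CCSc1nn2cc(-c3cc4ccccc4o3)nc2s1`: "not determined" (no result reported) in an assay for antagonist activity at proteinase-activated receptor 4 (Homo sapiens), with stated times of 5 min, 50 s and 15 min, in the presence of a further agent that is not named here; on this read-out lower numbers stand for stronger inhibition and higher numbers for weaker inhibition (no result reported)
- compound 2 `Cc1nn2cc(-c3cc4ccccc4o3)nc2s1`: > 30000 nM in this assay (a limit, not a number)
- compound 3 `CCOc1nn2cc(-c3cc4ccccc4o3)nc2s1`: 2100 nM in this assay

Among the measured compounds shown here, compound 3 holds the only number recorded in this assay; compound 2 sits at a limit and compound 1 has no entry. Of the measured pair, the value of compound 2 is a limit only (the limit of > 30000 nM in this assay, at which 1 of the 3 values shown sits). For the measured compounds named here, the single measured step, an at least 14-fold lower number from compound 2 to compound 3 (1.15 log units; beyond the scatter), shows that an exchange of the small group on the core of compound 3 moves the read-out strongly.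

Compound 4 `c1ccc2oc(-c3cn4nc(C5CC5)sc4n3)cc2c1` is not yet measured. Its change from compound 3 is cyclopropyl in place of ethoxy on an aromatic carbon. The measured step concerns methyl against ethoxy and does not cover cyclopropyl, so it bears only indirectly: it shows that this position is sensitive, but not which way a ring without an acceptor will move the number. The expectation is therefore a modest step, somewhat weaker, a 2.1-fold higher number from compound 3 to compound 4 (0.33 log units; beyond the scatter), with wide uncertainty. For compound 4 the estimate in this assay is 4500 nM, between 1000 nM and 20000 nM, with some chance that only a limit is returned.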

Compound 4, half-maximal inhibitory concentration: > 30000 nM
Compound 4 was reported as a limit; the forecaster's own chance of this, stated with the estimate: 20%; middle value at least 6.6-fold (0.82 log units) from the limit.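

In this assay, the result adds a second contrast at this position: an at least 14-fold higher number from compound 3 to compound 4 (1.15 log units; beyond the scatter). The earlier compounds shown here compared ethoxy only with methyl, so the smaller group could still be read as the shortfall, whereas here cyclopropyl and ethoxy both count 3 heavy atoms and the read-out still moves strongly, so heavy-atom count alone does not set the number at this carbon. Compound 2 and compound 4 both stand at a limit, so the step between them cannot be read, and ethoxy, the only one of these groups that counts a hydrogen-bond acceptor, is also the only one of the three to give a number rather than a limit: the limit of > 30000 nM in this assay, at which 2 of the 4 values shown sit.

With a single numerical value at this position, the link between that acceptor and the number remains a correlation across three compounds and not a tested rule. Open questions are whether a methoxy group, a longer alkoxy chain or an amine on this carbon would keep, improve or lose the inhibition seen with ethoxy, and how far any such gain would carry on the shared core.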